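Chloro-to-methoxy swap on a thiazole-fused series

The source may report more compounds than this note shows. Statements on the series, on what has been measured and on what is new or still open speak of the compounds shown alone.

Measured compounds in a functional assay on FM3A cells (Mus musculus) for inhibition, read by cell counting, with a stated time of 2 days; a lower number here means a stronger inhibitor, a higher number a weaker inhibitor:
compound 1, `Nc1cccc(-c2cn3nc(Cc4ccc(Cl)cc4)sc3n2)c1`, gives 6000 nM
compound 2, `COc1ccc(Cc2nn3cc(-c4cccc(N)c4)nc3s2)cc1`, gives 100000 nM
compound 3, `C=C(Br)C(=O)Nc1cccc(-c2cn3c(-c4ccc(Cl)cc4)csc3n2)c1`, gives 1100 nM

Compound 1 and compound 2 share a core and differ in one place: methoxy in place of chloro on an aromatic carbon. That single change produced a 17-fold higher number from compound 1 to compound 2 (1.22 log units; beyond the scatter), so the methoxy analogue is the weaker inhibitor of the pair by a wide margin.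

Compound 3 carries a different core and a different amide on the aniline; the difference between the cores of compound 1 and compound 3 is not broken down here. In this assay compound 3 stands lowest of the three measured numbers, beyond the scatter from both compound 1 and compound 2.

Compound 4, `C=C(Br)C(=O)Nc1cccc(-c2cn3c(-c4ccc(OC)cc4)csc3n2)c1`, has not yet been measured. It relates to compound 3 exactly as compound 2 relates to compound 1: methoxy in place of chloro on an aromatic carbon. The two places read the same word for word, so this is the same change made on a different core.

Within the data shown here, the only precedent for this change is the pair compound 1 and compound 2. Resting on that, the step from compound 3 to compound 4 is expected to be a 10-fold higher number from compound 3 to compound 4 (1.00 log units; beyond the scatter) in this assay, set somewhat smaller than the measured step because a 17-fold higher number from compound 1 to compound 2 (1.22 log units; beyond the scatter) is a single precedent on another core and carries limited weight. Compound 4 is accordingly expected to give about 11000 nM in this assay, with a plausible range from 3000 nM to 40000 nM.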

Compound 4, half-maximal inhibitory concentration: 620 nM
Compound 4: middle estimate off by 18-fold (1.25 log units), on the high side; measured number outside the range, below it.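

In this assay, methoxy in place of chloro gives a 1.8-fold lower number from compound 3 to compound 4 (0.25 log units; within the scatter), so on the core of compound 3 this swap leaves no difference that can be read, and compound 3 and compound 4 stand level within the scatter. The size of the step therefore does not carry from one core to the other, and the large loss seen with the free aniline has no counterpart in the amide pair: the same change on two cores in this assay, a 17-fold higher number (1.22 log units; beyond the scatter) from compound 1 to compound 2 and a 1.8-fold lower number (0.25 log units; within the scatter) from compound 3 to compound 4, 30-fold (1.47 log units) apart, beyond the scatter of two such steps

This does not show what sets the two steps apart, since the two pairs differ both in the core and in the group on the aniline nitrogen, and with one pair on each core no general rule for the swap can be drawn in this series.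

Open, going by these compounds, is how the swap reads with the free amine on the core of compound 3, or with the amide of compound 3 on the core of compound 1, either of which would separate the core from the amide. Also open, on these data alone, is how other groups in place of the chloro or methoxy, such as a hydroxyl, an amine or a carboxylic acid, behave on either core.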